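Swapping the Aryl Group on the Pyrrolidine Nitrogen

This account rests on a few compounds, and the source may have more. Where it says the series, first, only, none or still open, it means among the compounds named here.

Compound 1 `N#Cc1ccc(N2CC[C@@H](NC(=O)Nc3ccccc3Br)C2)nc1` is the lower of two measured compounds in a functional assay for antagonist activity at transient receptor potential cation channel subfamily V member 1 (Rattus norvegicus), read by FLIPR; on this read-out lower numbers stand for lower potency and higher numbers for higher potency (the scale is a negative logarithm): compound 1 gives 6.7, while compound 2 `O=C(Nc1ccccc1Br)N[C@@H]1CCN(c2cccc(C(F)(F)F)n2)C1` gives 7.2, a gap beyond the usual scatter. Compound 3 `O=C(Nc1ccccc1Br)N[C@@H]1CCN(c2cccc(F)c2)C1` has not been measured. It differs from compound 1 by 3-fluorophenyl in place of 5-cyanopyridin-2-yl on an amine nitrogen in a ring. Within the data shown here, no measured pair shows this change, so the step is expected to be small, with a slight upward lean, from compound 1 to compound 3 a number 0.20 log units higher from compound 1 to compound 3 (within the scatter), not clearly beyond the scatter. Compound 3 is therefore estimated at 6.9, with a range from 6.1 to 7.7.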

Compound 3, negative logarithm of the antagonist equilibrium constant: 7.8
Compound 3: middle estimate off by 0.90 log units, on the low side; the whole stated range lies below it.
By their numbers in this assay, from the lowest: compound 1; then compound 2; then compound 3.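

In this assay, the aryl group on the ring nitrogen turns out to be a strong lever on the number: 3-fluorophenyl in place of 5-cyanopyridin-2-yl gives a number 1.10 log units higher from compound 1 to compound 3 (beyond the scatter). This position therefore accepts a carbon-only aromatic ring with no nitrile, and the number rises well beyond the scatter. Nothing available accounts for the size of this step. Among these compounds, the single change swaps the ring nitrogen, the nitrile and the fluorine together, so their separate shares remain unresolved. On these data alone, whether an unsubstituted phenyl or a 3-chlorophenyl would hold this level also remains open.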